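The source may hold more compounds than are shown below. What is called first, only, known or untested is meant among the compounds shown, and "the series" means these compounds.

Three compounds share a core in which a five-membered non-aromatic ring with two nitrogens carries an aryl amide. Compound 1 `COc1ccc(C2CC(c3ccc(NC(=O)c4cc(Cl)ccc4OC)cc3)=NN2)cc1`, compound 2 `COc1ccc(Cl)cc1C(=O)Nc1ccc(C2=NNC(c3ccccc3[N+](=O)[O-])C2)cc1` and compound 3 `COc1ccc(C2CC(c3ccc(NC(=O)c4cc(Cl)ccc4OC)cc3)=NN2C(C)=O)cc1` have been tested in a functional assay on the whole organism (plasma, strain albino) for inhibition, with Rattus norvegicus as the target, with stated times of 1 h and 4 h, at a dose of 25 mg/kg by the oral route; a lower number here means a weaker effect, a higher number a stronger effect of the compound at the dose given; compound 4 `COc1ccc(Cl)cc1C(=O)Nc1ccc(C2=NN(C(C)=O)C(c3ccccc3[N+](=O)[O-])C2)cc1` has not. In this assay compound 1 gives 70.6%, compound 2 gives 72.3% and compound 3 gives 79.4%. The change from compound 1 to compound 2, (2-nitrophenyl in place of 4-methoxyphenyl on a saturated ring carbon), made a step of a number 1.7 percentage points higher from compound 1 to compound 2 (within the scatter). The core of compound 3 differs from that of compound 1 by acetyl in place of hydrogen on an amine nitrogen in a ring, a step of a number 8.8 percentage points higher from compound 1 to compound 3 (within the scatter). The change from compound 3 to compound 4, (2-nitrophenyl in place of 4-methoxyphenyl on a saturated ring carbon), is the same kind of change, though here the saturated ring carbon is next to the ring atom that bears an acetyl group. Because the earlier step was a number 1.7 percentage points higher from compound 1 to compound 2 (within the scatter), compound 4 is expected to move by about a number 1.6 percentage points higher from compound 3 to compound 4 (within the scatter) from compound 3. Compound 4 is therefore estimated at 81%, likely between 70% and 91%.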

Compound 4, a percentage reported as inhibition, in the whole organism at one dose (the size of the read-out at that dose, not a potency): 77.2%
Estimate against measurement, compound 4: 3.8 percentage points above, and the stated range covers the measured number.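

In this assay, 2-nitrophenyl in place of 4-methoxyphenyl on the acetylated core gives a step of a number 2.2 percentage points lower from compound 3 to compound 4 (within the scatter), and this agrees with the same change on the other core: the same change on two cores in this assay, a number 1.7 percentage points higher (within the scatter) from compound 1 to compound 2 and a number 2.2 percentage points lower (within the scatter) from compound 3 to compound 4, 3.9 percentage points apart, within the scatter of two such steps. Acetyl in place of hydrogen on the ring nitrogen of the 2-nitrophenyl core gives a step of a number 4.9 percentage points higher from compound 2 to compound 4 (within the scatter), which likewise agrees with its earlier counterpart: the same change on two cores in this assay, a number 8.8 percentage points higher (within the scatter) from compound 1 to compound 3 and a number 4.9 percentage points higher (within the scatter) from compound 2 to compound 4, 3.9 percentage points apart, within the scatter of two such steps. Neither change is seen to depend on the core across these four compounds, but with every step inside the scatter, this does not show that either change affects the read-out at all.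

The compounds shown leave open whether a carboxylic acid or an amine on the aromatic ring at the saturated ring carbon would move the read-out beyond the scatter. They also leave open whether a longer acyl chain than acetyl on the ring nitrogen would do so.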